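The compounds below may be only part of what the source reports. "The series", "measured", "known", "first", "only" and "open" are said of these compounds alone.

Compound 1 `CN(C)CCCNc1nc(-c2ccc(NC(=O)Nc3ccccc3Cl)cc2)nc2ccsc12`, compound 2 `CN(C)CCNc1nc(-c2ccc(NC(=O)Nc3ccccc3Cl)cc2)nc2ccsc12` and compound 3 `CCN(CC)CCNc1nc(-c2ccc(NC(=O)Nc3ccc(Cl)cc3)cc2)nc2ccsc12` share one core and one urea-linked aryl group, and differ in the amine-bearing chain and in where the chlorine sits on the outer phenyl ring. In a functional assay on NCI-H460 cells (Homo sapiens) for cytotoxicity, read by MTT assay, with a stated time of 72 h (a higher number here means a weaker inhibitor, a lower number a stronger inhibitor), compound 1 gives 430 nM, compound 2 gives 230 nM and compound 3 gives 190 nM. Among the compounds with values here, the only single-point step measured is a 1.9-fold lower number from compound 1 to compound 2 (0.27 log units; within the scatter). Compound 3 has the lowest number of the three, yet its gap to compound 2 lies within the scatter, so no order between those two can be claimed; only compound 1 stands clearly apart from it.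

Compound 4 `CCN(CC)CCNc1nc(-c2ccc(NC(=O)Nc3ccccc3Cl)cc2)nc2ccsc12` is the unmeasured partner of compound 3, with 2-chlorophenyl in place of 4-chlorophenyl on an amide-type nitrogen. Within the data shown here, no measured pair isolates this change: compounds 2 and 3 differ both in the chain amine and in the chlorine position, and their numbers sit within the scatter of each other, which gives no sign that either change matters much. The expectation is therefore a step of a 1.2-fold higher number from compound 3 to compound 4 (0.06 log units; within the scatter) in this assay, no clear direction. Compound 4 is estimated at 220 nM, with a range from 100 nM to 500 nM.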

Compound 4, half-maximal inhibitory concentration: 320 nM
Compound 4: middle estimate off by 1.5-fold (0.16 log units), on the low side; low and high end bracket the measured number.
By their numbers in this assay, from the lowest: compounds 3, 2, 4 and 1 (each within the scatter of the next, the first and the last beyond it).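

In this assay, within the data shown here, the step from 4-chlorophenyl to 2-chlorophenyl on the amide-type nitrogen, with the diethylamino chain kept the same, is a 1.7-fold higher number from compound 3 to compound 4 (0.23 log units; within the scatter) and is the first direct reading of this change, which does not separate the two chlorine placements. With 2-chlorophenyl kept the same, the amine end of the chain can also be read: diethylamino in place of dimethylamino gives a 1.4-fold higher number from compound 2 to compound 4 (0.14 log units; within the scatter) and diethylamino in place of (dimethylamino)methyl gives a 1.3-fold lower number from compound 1 to compound 4 (0.13 log units; within the scatter), so none of these single changes moves the number past the usual scatter. Nothing measured here offers an explanation for the size of any of these steps.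

Going by these compounds, whether a larger change would move the number past the scatter stays open, for example plain phenyl in place of the chlorophenyl group on the amide-type nitrogen, or morpholine in place of diethylamino on the chain. Also open, on these data alone, is whether the same chlorine change gives a similar step when the chain carries dimethylamino rather than diethylamino.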